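The compounds below may be only part of what the source reports. "The series", "measured", "known", "first", "only" and "open" are said of these compounds alone.

Measured so far:
Compound 1 `O=c1[nH]cnc2c1c(-c1ccoc1)cn2[C@@H]1O[C@H](CO)[C@@H](O)[C@H]1O` — in a functional assay on HeLa S3 cells (Homo sapiens) for antiproliferative activity, read by XTT assay, with a stated time of 72 h (a lower number here means a stronger inhibitor, a higher number a weaker inhibitor), compound 1 gives > 20000 nM, a limit of the assay and not a number.
Compound 2 `Cc1ncnc2c1c(-c1cc3ccccc3o1)cn2[C@@H]1O[C@H](CO)[C@@H](O)[C@H]1O` — compound 2 gives > 20000 nM, likewise a limit of the assay.
Compound 3 `Nc1nc2c(c(-c3ccoc3)cn2[C@@H]2O[C@H](CO)[C@@H](O)[C@H]2O)c(=O)[nH]1` — compound 3 gives 10700 nM.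

Compound 1 thus stands only at a limit; it shares that limit with compound 2, so that two of the three values sit there (the limit of > 20000 nM in this assay, at which 2 of the 3 values shown sit). Among the measured compounds shown here, the single measured step that starts from compound 1 is an at least 1.8-fold lower number from compound 1 to compound 3 (0.27 log units; that floor lies within the scatter), amino in place of hydrogen on an aromatic carbon, and its floor lies within the scatter.

Compound 4 `O=c1[nH]cnc2c1c(-c1ccccc1)cn2[C@@H]1O[C@H](CO)[C@@H](O)[C@H]1O` differs from compound 1 by phenyl in place of furan-3-yl on an aromatic carbon. For the measured compounds named here, no measured step alters the group at that position, so none of the steps bears directly on this change; the one step from compound 1 concerns another position of the core. Going by the values given here, with compound 1 at a limit and no guiding step, no movement beyond the scatter is expected, and the expected step is a step that the limit leaves unreadable from compound 1 to compound 4. Compound 4 is therefore estimated at 25000 nM, within 8000 nM to 80000 nM, with a fair chance that only a limit is reported again.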

Compound 4, half-maximal inhibitory concentration: > 20000 nM
Compound 4 ended at the assay's limit; the forecaster's own chance of this, stated with the estimate: 65%; the middle value does not contradict the limit.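

Compound 4 gives > 20000 nM and that is a limit, not a number. With compound 1 at a limit too, no step can be read between compound 1 and compound 4: the limit of > 20000 nM in this assay, at which 3 of the 4 values shown sit.
The compounds shown leave open how phenyl and furan-3-yl compare on the shared core.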